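Sulfonyl aryl variation on the shared core: compound 4

The compounds below may be only part of what the source reports. "The series", "measured", "known", "first", "only" and "open" are said of these compounds alone.

In an assay on isolated protein for displacement of a labelled ligand from metabotropic glutamate receptor 5 (Homo sapiens), with a stated time of 60 min, tested at 1 uM (a higher number here means more inhibition at the concentration tested (going by the name of the read-out), a lower number less inhibition), compound 3 `CC1CCN(c2c(S(=O)(=O)c3ccc(Cl)c(Cl)c3)cnc3ccc(Cl)cc23)CC1` gives 86%, the second highest of three numbers. Compound 1 `COc1ccc2ncc(S(=O)(=O)c3ccc(C)c(Cl)c3)c(N3CCC(C)CC3)c2c1` gives 85% and compound 2 `CC1CCN(c2c(S(=O)(=O)c3ccc(F)cc3)cnc3ccc(Cl)cc23)CC1` gives 89%; both sit within the scatter of compound 3. For the measured compounds named here, the one measured step on the sulfonyl aryl, a number 3 percentage points lower from compound 2 to compound 3 (within the scatter), is within the scatter. Compound 4 `Cc1ccc(S(=O)(=O)c2cnc3ccc(Cl)cc3c2N2CCC(C)CC2)cc1Cl` differs from compound 3 by methyl in place of chloro on an aromatic carbon. Compound 1 carries the same 3-chloro-4-methylphenyl on a sulfonyl sulfur, and its number in this assay lies close to that of compound 3, so no step beyond the scatter is expected here. For compound 4 the expected step is a number 1 percentage points lower from compound 3 to compound 4 (within the scatter). Compound 4 is estimated at 85% in this assay, with a range from 75% to 93%.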

Compound 4, a percentage reported as inhibition, at one concentration (the size of the read-out at that concentration, not a potency): 81%
For compound 4 the middle estimate is 4 percentage points above the measured one; the measured number falls inside the stated range.
By their numbers in this assay, from the lowest: compounds 4, 1, 3 and 2 (each within the scatter of the next).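

In this assay, methyl in place of chloro on the aromatic carbon para to a large group gives no step beyond the scatter (a number 5 percentage points lower from compound 3 to compound 4 (within the scatter)). The 3-chloro-4-methylphenyl group is likewise not separated from 4-fluorophenyl (a number 8 percentage points lower from compound 2 to compound 4 (within the scatter)), and with that aryl held fixed, neither is chloro in place of methoxy on the shared core (a number 4 percentage points lower from compound 1 to compound 4 (within the scatter)). No evidence on hand bears on these results.

Potency differences remain open, since these readings come from one concentration. Also open, as far as these compounds go, is whether an amine or a carboxylic acid at this position would give a step beyond the scatter.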